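Carboxy to carbamoyl: expected solubility of compound 3

The source may report more compounds than this note shows. Statements on the series, on what has been measured and on what is new or still open speak of the compounds shown alone.

Measured so far:
- compound 1, `CS(=O)(=O)c1ccc(-c2cnc(N)c(-c3ccc(N)nc3)n2)cc1`: 149000 nM
- compound 2, `Nc1ncc(-c2ccc(C(=O)O)cc2)nc1-c1ccc(C(F)(F)F)cc1`: 95000 nM

In a physicochemical assay for solubility, read by HPLC, using the shake flask method, in phosphate buffer, with a stated time of 2 h, at pH 6.5 (on this read-out lower numbers stand for lower solubility and higher numbers for higher solubility), compound 2 gives 95000 nM, the lower of the two numbers recorded so far; the nearest is compound 1 with 149000 nM, a gap that stays within the scatter, so the two stand level on this read-out.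

Compound 3, `NC(=O)c1ccc(-c2cnc(N)c(-c3ccc(C(F)(F)F)cc3)n2)cc1`, has not yet been measured. Relative to compound 2 the change is amino in place of hydroxy on a carbonyl carbon, so carboxy becomes carbamoyl on the carbon bearing the carbonyl while the rest of the structure is untouched. Going by the values given here, no measured pair in the set reports such a change, so the size of the step has no direct precedent here.

The expectation is a downward step: compound 3 is estimated at 20000 nM, within 3000 nM to 80000 nM, which means an expected step of a 4.8-fold lower number from compound 2 to compound 3 (0.68 log units; beyond the scatter) going beyond the scatter.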

Compound 3, solubility: < 5000 nM
Compound 3: only a limit was reported (the forecaster's own chance of this, stated with the estimate: 5%); middle value at least 4.0-fold (0.60 log units) from the limit.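

Going by these compounds alone, until now the series held no step between compounds differing in one place, so nothing showed how much a single change at this position could move the read-out. Amino in place of hydroxy on a carbonyl carbon whose other neighbour is an aromatic carbon gives an at least 19-fold lower number from compound 2 to compound 3 (1.27 log units; beyond the scatter) in this assay, a large step from a swap of one heavy atom. Compound 3 gives < 5000 nM, which is a limit of the assay and not a number, so how far the step extends stays unfixed: the limit of < 5000 nM in this assay, at which 1 of the 3 values shown sits.

Open, as far as these compounds go, is where other groups on this carbonyl carbon, such as a methyl ester or a methylamide, would fall relative to compound 2 and compound 3. Also open, from the compounds shown here alone, is whether the carboxy to carbamoyl step keeps its size when trifluoromethyl gives way to a chloro or methoxy group.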